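From a Trifluorophenyl Amide to a Fluoropyridyl Amide

The compounds below may be only part of what the source reports. "The series", "measured", "known", "first", "only" and "open" are said of these compounds alone.

Of the compounds shown here, three sharing one core have been measured in an ADME assay on LLC-MK2 cells (Macaca mulatta) for cytotoxicity, read by spectrophotometry and crystal violet staining, with a stated time of 4 days; on this read-out higher numbers stand for lower toxicity in this test and lower numbers for higher toxicity in this test.

Compound 1 `CC(C)n1ncc2c(C(=O)Nc3ccccn3)cc(-c3ccsc3)nc21` gives 25000 nM.
Compound 2 `CC(C)n1ncc2c(C(=O)Nc3c(F)cc(F)cc3F)cc(-c3cccs3)nc21` gives only a limit of the assay, > 200000 nM.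
Compound 3 `CC(C)n1ncc2c(C(=O)Nc3ncccn3)cc(-c3ccsc3)nc21` gives 50000 nM.

Compound 2 thus stands at the limit of > 200000 nM in this assay, at which 1 of the 3 values shown sits, and no number is known for it. Going by the values given here, the only step measured between neighbours that differ in one place is a 2.0-fold higher number from compound 1 to compound 3 (0.30 log units; within the scatter). Compound 4 `CC(C)n1ncc2c(C(=O)Nc3ccc(F)cn3)cc(-c3cccs3)nc21` has not been measured; it differs from compound 2 by 5-fluoropyridin-2-yl in place of 2,4,6-trifluorophenyl on an amide-type nitrogen. The measured step swaps one six-membered ring with hetero atoms for another on the amide-type nitrogen, whereas the change from compound 2 to compound 4 replaces a carbon-only ring by a ring with one hetero atom, so that step does not cover it. What the numbers do show is where the pyridin-2-yl and pyrimidin-2-yl relatives, compound 1 and compound 3, sit. Guided by the value of compound 1, compound 4 is expected to give an estimated 35000 nM, within a range from 10000 nM to 200000 nM. The step this implies, an at least 5.7-fold lower number from compound 2 to compound 4 (0.75 log units; beyond the scatter), is an expectation only, since the starting point is a limit and not a number.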

Compound 4, half-maximal cytotoxic concentration: > 200000 nM
Compound 4: only a limit was reported; the forecaster's own chance of this, stated with the estimate: 20%; at least 5.7-fold (0.75 log units) between middle value and limit.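

In this assay compound 4 gives > 200000 nM, a limit of the assay and not a number. Compound 2 stands at the same limit, so no step can be read between compound 2 and compound 4: the limit of > 200000 nM in this assay, at which 2 of the 4 values shown sit.

The compounds shown leave open whether 5-fluoropyridin-2-yl or 2,4,6-trifluorophenyl on the amide-type nitrogen gives the higher number.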